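Replacing an aryloxy group by a pyrrolyl ring

The source may hold more compounds than are shown below. What is called first, only, known or untested is meant among the compounds shown, and "the series" means these compounds.

Compound 1, `COc1cc(OC)c2c(=O)cc(C(=O)Nc3ccc(C4CCCCC4)cc3)[nH]c2c1`: 18400 nM
Compound 2, `COc1cc(OC)c2c(=O)cc(C(=O)Nc3ccc(Oc4cccnc4)cc3)[nH]c2c1`: > 32100 nM

In a functional assay on KOPN-8 cells (Homo sapiens) for antiproliferative activity, with a stated time of 72 h (a higher number here means that more compound is needed for the effect, a lower number that less compound is needed), compound 1 gives 18400 nM. For compound 2 the result is a limit of the assay rather than a number, > 32100 nM. Among the compounds with values here, the single measured step, an at least 1.7-fold higher number from compound 1 to compound 2 (0.24 log units; that floor lies within the scatter), therefore rests on (the limit of > 32100 nM in this assay, at which 1 of the 2 values shown sits), and its true size is not known. Compound 2 thus stands at the weak end of what has been measured, with only a limit to mark its place.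

Compound 3, `COc1cc(OC)c2c(=O)cc(C(=O)Nc3ccc(-n4cccc4)cc3)[nH]c2c1`, differs from compound 2 in one place: 1H-pyrrol-1-yl in place of (pyridin-3-yl)oxy on an aromatic carbon. Within the data shown here, no measured step bears directly on this exchange; the only step available, an at least 1.7-fold higher number from compound 1 to compound 2 (0.24 log units; that floor lies within the scatter), concerns a different replacement at the same position and is itself bounded by a limit. What can be said is that both measured compounds lie at weak potency, so a large gain is not expected. Compound 3 is expected to give about 25000 nM in this assay, with a range from 7000 nM to 90000 nM. That estimate means an expected step of an at least 1.2-fold lower number from compound 2 to compound 3 (0.10 log units; that floor lies within the scatter), and a limit remains a real possibility.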

Compound 3, half-maximal effective concentration: > 77000 nM
Compound 3 ended at the assay's limit; the forecaster's own chance of this, stated with the estimate: 45%; at least 3.0-fold (0.48 log units) between middle value and limit.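

In this assay, compound 3 gives > 77000 nM, which is a limit of the assay and not a number. Exchanging cyclohexyl for 1H-pyrrol-1-yl on this aromatic carbon gives an at least 4.1-fold higher number from compound 1 to compound 3 (0.62 log units; beyond the scatter), so this position now has a change whose floor stands clear of the scatter, something the earlier exchange of cyclohexyl for (pyridin-3-yl)oxy could not show. Compound 2 and compound 3 both end in limits, and the step between them cannot be read, so neither the size nor the direction of the exchange of (pyridin-3-yl)oxy for 1H-pyrrol-1-yl is known.

Of the three compounds, only compound 1 carries a real number, 18400 nM, which leaves open how far the two aromatic replacements truly lie from it. The compounds shown also leave open whether a different group on this carbon, such as an amine, a carboxylic acid or a longer alkyl chain, would give a measured number in this assay rather than a limit, and whether any such group would need less compound than cyclohexyl does.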